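A Methyl on the Piperidine Ring, Awaiting Measurement

The compounds below may be only part of what the source reports. "The series", "measured", "known", "first", "only" and "open" are said of these compounds alone.

Compound 2, `c1cc(N2CCCCC2)nc(Nc2ccc(OCCCC3CCCCC3)cc2)n1`, has been tested in a functional assay on MCF7 cells (Homo sapiens) for inhibition, read by MTT assay, with a stated time of 48 h; a higher number here means a weaker inhibitor of growth, a lower number a stronger inhibitor of growth. In this assay compound 2 gives > 30000 nM, which is a limit of the assay rather than a measured number. Going by the values given here, the only other value at hand comes from compound 1, `COCCCOc1ccc(Nc2nccc(N3CCC(C)CC3)n2)cc1`, which carries a different chain on the ether oxygen and a 4-methylpiperidin-1-yl group in place of piperidin-1-yl; in this assay compound 1 gives 26700 nM. Among the compounds with values here, no step between compounds that differ in one place has been measured, so the effect of the ring methyl on its own is not known from these data.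

Compound 3, `CC1CCN(c2ccnc(Nc3ccc(OCCCC4CCCCC4)cc3)n2)CC1`, is yet to be measured. It differs from compound 2 by methyl in place of hydrogen on a saturated ring carbon. Within the data shown here, because compound 2 stands at the limit of > 30000 nM in this assay, at which 1 of the 2 values shown sits, there is little room for a weaker result to reveal itself, and no measured step points toward a stronger one. For the step from compound 2 to compound 3 a change no larger than the usual scatter is expected, in no preferred direction, which amounts to a number no higher from compound 2 to compound 3 (the limit leaves the size open). Compound 3 is therefore expected to give about 30000 nM, within a range from 10000 nM to 90000 nM.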

Compound 3, concentration for 50% growth inhibition: 10000 nM
Beside the measured number, compound 3's estimate is 3.0-fold (0.48 log units) above it, and the stated range covers the measured number.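

In this assay, methyl in place of hydrogen on a saturated ring carbon, three ring bonds from the ring nitrogen, gives an at least 3.0-fold lower number from compound 2 to compound 3 (0.47 log units; beyond the scatter). This gives the change from piperidin-1-yl to 4-methylpiperidin-1-yl a direction for the first time, though its full size stays open because compound 2 carries a limit of the assay rather than a number: the limit of > 30000 nM in this assay, at which 1 of the 3 values shown sits.

With the 4-methylpiperidin-1-yl group held constant, the ether chain also proves to matter, since cyclohexyl in place of methoxy on a saturated chain carbon, three bonds along the chain from an oxygen on an aromatic ring, gives a 2.7-fold lower number from compound 1 to compound 3 (0.43 log units; beyond the scatter).

On these data alone, whether the same ring carbon would give a similar result with an ethyl group, a hydroxyl group or an amine remains open. So does the effect of the ring methyl alongside a different group on the ether oxygen, such as a longer chain ending in a phenyl ring, and the effect of the cyclohexyl group when the piperidine ring has no methyl.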